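The source may hold more compounds than are shown below. What is called first, only, known or untested is meant among the compounds shown, and "the series" means these compounds.

Measured compounds: compound 1 `CC1CCN(C2CCN(S(=O)(=O)c3ccc(C#N)cc3)CC2)CC1` gives 2800 nM; compound 2 `CC1CCN(C2CCN(S(=O)(=O)c3cccnc3)CC2)CC1` gives 2400 nM; compound 3 `CC1CCN(C2CCN(S(=O)(=O)c3ccc(OCc4ccccc4)cc3)CC2)CC1` gives 385 nM.

All three were tested in a functional assay on DLD-1 cells (Homo sapiens) for antiproliferative activity, read by CellTiter-Glo, with a stated time of 72 h; a lower number here means a stronger inhibitor, a higher number a weaker inhibitor. Compound 3 stands lowest of the three numbers: the step from compound 1 to compound 3 was a 7.3-fold lower number from compound 1 to compound 3 (0.86 log units; beyond the scatter), and compound 3 also lies beyond the scatter below compound 2. The exchange a 1.2-fold lower number from compound 1 to compound 2 (0.07 log units; within the scatter) changed the ring on the sulfonyl sulfur and showed no movement.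

Compound 4 `CCc1ccc(S(=O)(=O)N2CCC(N3CCC(C)CC3)CC2)cc1` differs from compound 3 by ethyl in place of benzyloxy on an aromatic carbon. Within the data shown here, the one step that bears on this position is a 7.3-fold lower number from compound 1 to compound 3 (0.86 log units; beyond the scatter), where a small group gave way to benzyloxy and the number fell; ethyl brings two heavy atoms where benzyloxy had eight, so some of that gain is expected to be given back, with a step of a 3.9-fold higher number from compound 3 to compound 4 (0.59 log units; beyond the scatter). Compound 4 is estimated at 1500 nM, between 500 nM and 4500 nM.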

Compound 4, half-maximal inhibitory concentration: > 5000 nM
Compound 4: a limit, no number; the forecaster's own chance of this, stated with the estimate: 5%; at least 3.3-fold (0.52 log units) between middle value and limit.
By their numbers in this assay, from the lowest: compound 3; then compounds 2 and 1 (each within the scatter of the next). At a limit, above all of these: compound 4.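

The value of compound 4 is a limit of the assay and not a number: the limit of > 5000 nM in this assay, at which 1 of the 4 values shown sits. Ethyl in place of benzyloxy gave an at least 12-fold higher number from compound 3 to compound 4 (1.11 log units; beyond the scatter), so the gain seen with benzyloxy does not carry over to ethyl. Against the other two compounds, 4-ethylphenyl in place of pyridin-3-yl gave an at least 2.0-fold higher number from compound 2 to compound 4 (0.31 log units; beyond the scatter), while ethyl in place of cyano gave an at least 1.7-fold higher number from compound 1 to compound 4 (0.25 log units; that floor lies within the scatter), which does not separate those two groups.

On these data alone, whether the gain depends on the oxygen or on the aromatic ring of benzyloxy stays open. A methoxy group, a phenyl group or a longer alkoxy chain at this place would divide the two.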